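The source may report more compounds than this note shows. Statements on the series, on what has been measured and on what is new or still open speak of the compounds shown alone.

Measured compounds in a functional assay for agonist activity at G protein-coupled receptor 88 (Homo sapiens), read by HTRF and cAMP accumulation; a lower number here means that less compound is needed, a higher number that more compound is needed for the effect: compound 1 `CC(C)C[C@H](N)CN(C(=O)[C@@H]1C[C@H]1c1ccccc1)c1ccc(-c2ccncc2)cc1` gives 13000 nM; compound 2 `CC(C)C[C@H](N)CN(C(=O)[C@@H]1C[C@H]1c1ccccc1)c1ccc(-c2ccsc2)cc1` gives 1200 nM; compound 3 `COc1ccccc1-c1ccc(N(C[C@@H](N)CC(C)C)C(=O)[C@@H]2C[C@H]2c2ccccc2)cc1` gives 3200 nM.

Compound 3 stands second highest of the three numbers in this assay: a 2.7-fold higher number from compound 2 to compound 3 (0.43 log units; beyond the scatter), while a 4.1-fold lower number from compound 1 to compound 3 (0.61 log units; beyond the scatter). Every measured step exchanges the whole aryl group attached to the shared core, and the sizes vary: an 11-fold lower number from compound 1 to compound 2 (1.03 log units; beyond the scatter); a 4.1-fold lower number from compound 1 to compound 3 (0.61 log units; beyond the scatter); a 2.7-fold higher number from compound 2 to compound 3 (0.43 log units; beyond the scatter).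

Compound 4 `CC(C)C[C@H](N)CN(C(=O)[C@@H]1C[C@H]1c1ccccc1)c1ccc(-c2ccccc2Cl)cc1` differs from compound 3 by chloro in place of methoxy on an aromatic carbon. Among the measured compounds shown here, none of the measured steps keeps this ring and alters only one substituent on it, so no step bears directly on the change. The closest comparison, which swaps the ring itself, is the step from compound 2 to compound 3, and that swap was beyond the scatter but not large. Without a direct precedent, the expected step of a 1.1-fold lower number from compound 3 to compound 4 (0.03 log units; within the scatter) is small, within or close to the scatter, with no firm direction. Compound 4 is therefore estimated at 3000 nM in this assay, with a range from 1000 nM to 9000 nM.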

Compound 4, half-maximal effective concentration: 3800 nM
Compound 4: the middle estimate sits 1.3-fold (0.10 log units) below what was measured; the range from low to high includes it.
By their numbers in this assay, from the lowest: compound 2; then compounds 3 and 4 (each within the scatter of the next); then compound 1.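

In this assay, among the compounds shown here, chloro in place of methoxy on this aromatic carbon, ortho to a large group, gives a 1.2-fold higher number from compound 3 to compound 4 (0.07 log units; within the scatter), so these two substituents cannot be told apart in the first exchange that keeps the ring and alters only the substituent. The 2-chlorophenyl group stands much where the 2-methoxyphenyl group stood relative to the other two aryl groups, with a 3.2-fold higher number from compound 2 to compound 4 (0.50 log units; beyond the scatter) and a 3.4-fold lower number from compound 1 to compound 4 (0.53 log units; beyond the scatter). No supporting measurement accounts for the equivalence of chloro and methoxy here.

Open is whether any substituent at this place matters, since the compounds shown include no plain phenyl group for comparison. A methyl, a fluoro or an amine on the same carbon would show whether the tolerance seen with chloro and methoxy extends further, and whether a substituted phenyl can reach the number of compound 2.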